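Swapping the group on the amide carbonyl: compound 2 to compound 3

The compounds below may be only part of what the source reports. "The series", "measured", "known", "first", "only" and "open" are said of these compounds alone.

Measured so far in a toxicity assay on THP-1 cells (Homo sapiens) for inhibition; on this read-out higher numbers stand for lower toxicity in this test and lower numbers for higher toxicity in this test:
- compound 1 `COc1ccc(-c2cnc(NC(=O)c3ccccc3C#N)n2C)cc1`: > 100000 nM (a limit)
- compound 2 `COc1ccc(C(=O)Nc2ncc(-c3ccc(OC)cc3)n2C)cc1`: > 100000 nM (a limit)

In this assay compound 2 stands at > 100000 nM, which is a limit and not a number. For the measured compounds named here, neither measured compound has a numerical value so far, and the only reading is the limit of > 100000 nM in this assay, at which 2 of the 2 values shown sit.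

Compound 3 `COc1ccc(-c2cnc(NC(=O)c3ccccn3)n2C)cc1` keeps the core of compound 2 and differs in one place, with pyridin-2-yl in place of 4-methoxyphenyl on a carbonyl carbon.

Going by the values given here, one measured step bears on this change, as it falls on the same carbonyl carbon: a step that the two limits leave unreadable from compound 1 to compound 2. Its size cannot be read, so it offers no measured shift to carry over. The expectation therefore rests on a step that the two limits leave unreadable from compound 1 to compound 2 and allows no step beyond the scatter in either direction in this assay. The expected size is a number no higher from compound 2 to compound 3 (the limit leaves the size open). A further report of a limit alone is the likeliest outcome.

For compound 3 the estimated value is 100000 nM, with an expected range from 40000 nM to 200000 nM.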

Compound 3, half-maximal cytotoxic concentration: > 100000 nM
Compound 3: a limit, no number; the forecaster's own chance of this, stated with the estimate: 85%; the middle value sits exactly at the limit.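

In this assay compound 3 gives > 100000 nM, a limit and not a number. No new step can be read among compound 1, compound 2 and compound 3. These compounds leave open whether the group on the carbonyl carbon changes toxicity in this assay at all, since no numerical value exists to compare, only this reading: the limit of > 100000 nM in this assay, at which 3 of the 3 values shown sit.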